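Formyl alkene in place of the diol end

This account rests on a few compounds, and the source may have more. Where it says the series, first, only, none or still open, it means among the compounds named here.

- compound 1 (`C=C[C@@](C)(/C=C/c1ccc(OCc2ccccc2)cc1)CCC=C(C)C`) gives > 49000 nM as a limit
- compound 2 (`C=C[C@](C)(CCCC(C)C)CCc1ccc(O)cc1`) gives > 49000 nM as a limit
- compound 3 (`C=C[C@@](C)(/C=C/c1ccc(O)cc1)CCC(O)C(C)(C)O`) gives > 49000 nM as a limit

All three results are limits in a functional assay on Jurkat cells (Homo sapiens) for cytotoxicity, with a stated time of 72 h (on this read-out lower numbers stand for an effect already at smaller amounts and higher numbers for an effect only at larger amounts of compound), and none is a number. For compound 3 the position is the limit of > 49000 nM in this assay, at which 3 of the 3 values shown sit, and no value of its own is known.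

Compound 4 (`C=C[C@@](C)(/C=C/c1ccc(O)cc1)CC/C=C(\C)C=O`) differs from compound 3 in the side chain (2-formylprop-1-en-1-yl in place of 1,2-dihydroxy-2-methylpropyl on a saturated chain carbon, three bonds along the chain from two double-bonded chain carbons) with 2-formylprop-1-en-1-yl in place of 1,2-dihydroxy-2-methylpropyl on a saturated chain carbon. Among the measured compounds shown here, no measured step gives a size, so the expectation rests on this change alone. An effect at smaller amounts is expected, with an estimated at least 1.9-fold lower number from compound 3 to compound 4 (0.29 log units; that floor lies within the scatter) that remains rough, and a further limit is also possible. Compound 4 is expected at 25000 nM with an estimated range from 8000 nM to 60000 nM on this read-out.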

Compound 4, half-maximal effective concentration: > 49000 nM
Compound 4: only a limit was reported; the forecaster's own chance of this, stated with the estimate: 45%; at least 1.9-fold (0.29 log units) between middle value and limit.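

Compound 4 gives > 49000 nM, a limit, so no step from compound 3 to compound 4 can be read: the limit of > 49000 nM in this assay, at which 4 of the 4 values shown sit.

Still open, from the compounds shown here alone, is whether 2-formylprop-1-en-1-yl in place of 1,2-dihydroxy-2-methylpropyl changes the effect at all, and at what amount compound 3 or compound 4 would act.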